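A few compounds are considered here, and "the series" means these few. Any claim that something is new, unique, unknown or untested is made for them only; others in the source may bear on it.

Measured so far in an assay on A7R5 cells for inhibition of Rho-associated protein kinase 2 (Rattus norvegicus), with a stated time of 1 h; a higher number here means a weaker inhibitor, a lower number a stronger inhibitor:
Compound 1 `COc1ccc2c(c1)C[C@@H](C(=O)Nc1ccc(-c3cn[nH]c3)cc1O[C@@H]1CCN(C)C1)CO2` gives 32 nM.
Compound 2 `COc1ccc2c(c1)C[C@H](C(=O)Nc1ccc(-c3cn[nH]c3)cc1O[C@@H]1CCN(C)C1)CO2` gives < 4 nM, which is a limit of this assay and not a number.

Compound 2 thus stands at the stronger end of the pair, though only a limit is known for it (the limit of < 4 nM in this assay, at which 1 of the 2 values shown sits). Compound 3 `COc1ccc2c(c1)C[C@H](C(=O)Nc1ccc(-c3cn[nH]c3)cc1O[C@H]1CCN(C)C1)CO2` differs from it in one respect: the two compounds have the same atoms and bonds and differ only in configuration as drawn: 1 of 2 stereo elements differ; a stereocentre at a saturated ring carbon is drawn R in compound 2 and S in compound 3. Within the data shown here, the one measured step, an at least 8.0-fold lower number from compound 1 to compound 2 (0.90 log units; beyond the scatter), inverted the other of the two stereo elements (the fact that compounds 1 and 2 differ only in the configuration as drawn), so it does not bear directly on this change; it does show that configuration alone can move the number beyond the scatter here. Since compound 2 reports only a limit (the limit of < 4 nM in this assay, at which 1 of the 2 values shown sits), a further gain could not register, whereas a loss could. The account therefore expects a step of an at least 3.0-fold higher number from compound 2 to compound 3 (0.47 log units; beyond the scatter), with its direction uncertain. For compound 3 the estimated value in this assay is 12 nM, with a range from 2 nM to 70 nM.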

Compound 3, half-maximal inhibitory concentration: < 4 nM
Compound 3 ended at the assay's limit; the forecaster's own chance of this, stated with the estimate: 30%; middle value at least 3.0-fold (0.47 log units) away from the limit.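

In this assay compound 3 gives < 4 nM, which is a limit of the assay and not a number. So the second stereocentre can be drawn either way, with the first kept as in compound 2, and the value still reaches the limit; the step between compound 2 and compound 3 cannot be read, since both values are limits, and the only thing separating the two is this: the fact that compounds 2 and 3 differ only in the configuration as drawn. The mirror-image pair gives an at least 8.0-fold lower number from compound 1 to compound 3 (0.90 log units; beyond the scatter), so the number moves beyond the scatter when both stereocentres are inverted, a step of the same printed size as an at least 8.0-fold lower number from compound 1 to compound 2 (0.90 log units; beyond the scatter).

As far as these compounds go, how far compound 2 and compound 3 lie apart beneath the limit remains open, as does the value of the fourth combination of the two stereocentres. Also open, from the compounds shown here alone, is whether a secondary amine in place of the methylated ring amine, or a longer chain on that nitrogen, would stay at the limit.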